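Swapping the ether-linked pyrimidine for a pyridinylethyl chain

The source may report more compounds than this note shows. Statements on the series, on what has been measured and on what is new or still open speak of the compounds shown alone.

Compound 2 `O=C(COCc1ccncn1)N1CCN(c2ccc(Cl)cc2Cl)CC1` has the highest number of the three measured compounds in a functional assay on HEK293 cells for positive allosteric modulation of metabotropic glutamate receptor 5 (Homo sapiens), read by FLIPR and calcium flux (a lower number here means that less compound is needed, a higher number that more compound is needed for the effect), giving 2800 nM. Compound 1 `O=C(COCc1ccccc1)N1CCN(c2ccc(Cl)cc2Cl)CC1` gives 1000 nM, and compound 3 `N#Cc1ccc(COCC(=O)N2CCN(c3ccc(Cl)cc3Cl)CC2)s1` gives 210 nM. The step of a 2.8-fold higher number from compound 1 to compound 2 (0.45 log units; beyond the scatter) shows the pyrimidine as the weaker choice, while a 4.8-fold lower number from compound 1 to compound 3 (0.68 log units; beyond the scatter) and a 13-fold lower number from compound 2 to compound 3 (1.12 log units; beyond the scatter) favour the cyanothiophene. Compound 4 `O=C(CCCc1ccncc1)N1CCN(c2ccc(Cl)cc2Cl)CC1` differs from compound 2 by 2-(pyridin-4-yl)ethyl in place of (pyrimidin-4-yl)methoxy on a saturated chain carbon bound to a carbonyl carbon. Among the measured compounds shown here, no measured step changes the linker in this way, so the direction is uncertain; a pyridine sits between phenyl and pyrimidine in heteroatom count, which hints at a modest gain. Compound 4 is therefore expected at about 2000 nM, within 500 nM to 8000 nM, an estimated step of a 1.4-fold lower number from compound 2 to compound 4 (0.15 log units; within the scatter) in this assay.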

Compound 4, half-maximal effective concentration: 5300 nM
For compound 4 the middle estimate is 2.7-fold (0.42 log units) below the measured one; low and high end bracket the measured number.
By their numbers in this assay, from the lowest: compound 3; then compound 1; then compounds 2 and 4 (each within the scatter of the next).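

In this assay, the change from (pyrimidin-4-yl)methoxy to 2-(pyridin-4-yl)ethyl gives a 1.9-fold higher number from compound 2 to compound 4 (0.28 log units; within the scatter), so these two groups cannot be told apart at this position. Measured against the benzyloxy group, the same new group gives a 5.3-fold higher number from compound 1 to compound 4 (0.72 log units; beyond the scatter), which places it with the pyrimidine rather than with the phenyl ring of compound 1. No measurement here offers an explanation for either step. Both steps alter the ring and the chain together, so the share of the oxygen remains unresolved. A 2-phenylethyl or a (pyridin-4-yl)methoxy group would separate the two changes.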